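Growing the Ring on a Thiocarbonyl Carbon

The source may report more compounds than this note shows. Statements on the series, on what has been measured and on what is new or still open speak of the compounds shown alone.

This series is measured in an ADME assay on HEK293 cells (Homo sapiens) for inhibition, read by MTT assay, with stated times of 18 h and 4 h; a lower number here means a stronger inhibitor, a higher number a weaker inhibitor. Compound 1 `CCCCCCCCOP(=O)(O)OCCSC(=S)N1CCCC1` gives 28300 nM. Compound 3 `CCCCCCCCOP(=O)(O)OCCSC(=S)N1CCCCC1` gives 69000 nM, and compound 2 `CCCCCCCCCCOP(=O)(O)OCCSC(=S)N1CCCCCC1`, which carries azepan-1-yl, gives 70000 nM. These last two values lie within the scatter of each other, so compound 3 sits level with compound 2 and well clear of compound 1.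

The next compound, compound 4 `CCCCCCCCOP(=O)(O)OCCSC(=S)N1CCCCCC1`, keeps the rest of compound 3 and changes one group on a thiocarbonyl carbon: azepan-1-yl in place of piperidin-1-yl on a thiocarbonyl carbon. The six-membered ring of piperidin-1-yl gives way to the seven-membered ring of azepan-1-yl.

Going by the values given here, one measured step bears on this change. Going from pyrrolidin-1-yl to piperidin-1-yl gave a modest rise, a 2.4-fold higher number from compound 1 to compound 3 (0.39 log units; beyond the scatter). That single step cannot show whether the trend continues with a larger ring. The value of compound 2 at 70000 nM offers no sign of a sharp shift with azepan-1-yl in place. A small upward move in this assay therefore seems likeliest, and it may well not exceed the scatter. The expected change is a 1.2-fold higher number from compound 3 to compound 4 (0.06 log units; within the scatter). For compound 4 the estimated value is 80000 nM, with an expected range from 40000 nM to 160000 nM.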

Compound 4, half-maximal inhibitory concentration: > 100000 nM
Compound 4 ended at the assay's limit; the forecaster's own chance of this, stated with the estimate: 15%; middle value at least 1.2-fold (0.09 log units) from the limit.
By their numbers in this assay, from the lowest: compound 1; then compounds 3 and 2 (each within the scatter of the next). At a limit, above all of these: compound 4.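

Compound 4 stands at a limit of the assay, not at an exact number: the limit of > 100000 nM in this assay, at which 1 of the 4 values shown sits. In this assay, the full ring change gives an at least 3.5-fold higher number from compound 1 to compound 4 (0.54 log units; beyond the scatter), which shows that the seven-membered ring is clearly separated from the five-membered ring and that the number does not fall back on moving past the six-membered ring. The direct ring change, an at least 1.4-fold higher number from compound 3 to compound 4 (0.16 log units; that floor lies within the scatter), and the chain change at a fixed azepan-1-yl ring, an at least 1.4-fold higher number from compound 2 to compound 4 (0.15 log units; that floor lies within the scatter), each have a floor within the scatter, so neither of these two steps alone establishes a real separation.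

All the groups shown at this position are saturated rings holding one nitrogen, which leaves open how an azetidin-1-yl ring, a morpholin-4-yl ring or an open-chain diethylamino group would read in this assay. Going by these compounds alone, it also remains open whether a decyl chain paired with pyrrolidin-1-yl or piperidin-1-yl would shift the number, since the only decyl compound here carries azepan-1-yl.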